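The source may report more compounds than this note shows. Statements on the series, on what has been measured and on what is new or still open speak of the compounds shown alone.

Compound 1 `COc1cc(-c2cc(/C=C/C(=O)c3ccc(Cl)c(Cl)c3)[nH]n2)cc(OC)c1OC` gives 8650 nM in a functional assay on MDA-MB-231 cells (Homo sapiens) for inhibition, read by sulforhodamine B assay, with a stated time of 48 h; on this read-out lower numbers stand for stronger inhibition of growth and higher numbers for weaker inhibition of growth.
Compound 2 `COc1ccc(-c2cc(/C=C/C(=O)c3cc(OC)c(OC)c(OC)c3)[nH]n2)cc1OC` gives 2020 nM in this assay.
Compound 3 `COc1ccc(C(=O)/C=C/c2cc(-c3cc(OC)c(OC)c(OC)c3)n[nH]2)cc1` gives 1880 nM in this assay.

Compound 3 has the lowest number of the three, but compound 2 stands within the scatter of it, so these two cannot be ordered; only compound 1 sits clearly apart, with the higher number.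

Compound 4 `COc1cc(-c2cc(/C=C/C(=O)c3ccc(F)c(F)c3)[nH]n2)cc(OC)c1OC` has not yet been measured. It differs from compound 3 in one place: 3,4-difluorophenyl in place of 4-methoxyphenyl on a carbonyl carbon. Within the data shown here, the one measured step at the same carbonyl carbon is a 4.6-fold lower number from compound 1 to compound 3 (0.66 log units; beyond the scatter), where 3,4-dichlorophenyl gave way to 4-methoxyphenyl and the number dropped. Among the measured compounds shown here, the change to compound 4 runs the opposite way, replacing the 4-methoxyphenyl with a 3,4-difluorophenyl, a ring close in pattern to the 3,4-dichlorophenyl of compound 1 but carrying fluorine instead of chlorine, so no measured step matches it exactly. A rise in the number is therefore expected in this assay, probably somewhat smaller than the measured step, since the ring entering is not the one that left in that step. Compound 4 is expected to give about 5000 nM, within 2000 nM to 14000 nM, which means an expected step of a 2.7-fold higher number from compound 3 to compound 4 (0.42 log units; beyond the scatter).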

Compound 4, concentration for 50% growth inhibition: 1640 nM
Compound 4: the middle estimate sits 3.0-fold (0.48 log units) above what was measured; the whole stated range lies above it.
By their numbers in this assay, from the lowest: compounds 4, 3 and 2 (each within the scatter of the next); then compound 1.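

In this assay, swapping 3,4-dichlorophenyl for 3,4-difluorophenyl on the carbonyl carbon, with the rest of the molecule unchanged, gives a clear difference (a 5.3-fold lower number from compound 1 to compound 4 (0.72 log units; beyond the scatter)) that lies beyond the scatter, so two rings with the same substitution pattern are not interchangeable here. Replacing 4-methoxyphenyl with 3,4-difluorophenyl gives only a 1.1-fold lower number from compound 3 to compound 4 (0.06 log units; within the scatter) and that lies within the scatter, so compound 3 and compound 4 cannot be ordered, and among compounds 1, 3 and 4 the higher number goes with the 3,4-dichlorophenyl ring rather than with halogens on this ring as such. Nothing available explains why chlorine and fluorine part ways here, or why a ring with a methoxy group matches one with two fluorines.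

The compounds shown leave open whether this position would also accept an unsubstituted phenyl, a ring with a single chlorine or a single fluorine, or a ring carrying an amine or a carboxylic acid. They also leave open how far the numbers depend on the rest of the core, which stays the same across compounds 1, 3 and 4.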